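The compounds below may be only part of what the source reports. "The series", "measured", "known", "first", "only" and "open" are said of these compounds alone.

Measured so far:
compound 1 `CCc1nc2ccccc2n1CCCCOc1cccc(C)c1` — 19 uM
compound 2 `CCc1nc2ccc(Cl)cc2n1CCCCOc1ccccc1` — 25 uM
compound 3 `Nc1nc2ccccc2n1CCCCOc1ccccc1` — "not determined" (no result reported)

In an ADME assay on Vero cells (Chlorocebus sabaeus) for cytotoxicity, read by luminescence, with a stated time of 2 days (a higher number here means that more compound is tolerated, a lower number that less compound is tolerated), compound 1 gives 19 uM. In this assay compound 2 gives 25 uM; the gap between the two lies within the usual scatter, so neither compound is set apart from the other on these numbers. Compound 3 has no number in this assay, so nothing can be read from it. Among the compounds with values here, only two numbers stand in this assay, and compound 1 holds the lower of them, with compound 2 close by.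

Compound 4 `CCc1nc2ccccc2n1CCCCOC` differs from compound 1 in one place: methyl in place of 3-methylphenyl on an oxygen on a saturated carbon. Within the data shown here, no pair of measured compounds shows a change of this kind, so there is no measured step to lean on, and the expectation rests on the anchor value of compound 1 alone. The shared core and the saturated chain are kept; only the group on the oxygen is exchanged. Taking compound 1 as the anchor, a modest move toward a higher number is expected, near the edge of the scatter rather than well beyond it. The step from compound 1 to compound 4 is estimated at a 2.1-fold higher number from compound 1 to compound 4 (0.32 log units; beyond the scatter). Compound 4 is expected to give 40 uM in this assay, with a range of 15 uM to 100 uM; a result reported only as a limit cannot be ruled out.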

Compound 4, half-maximal toxic concentration: > 50 uM
Compound 4 was reported as a limit (the forecaster's own chance of this, stated with the estimate: 30%); middle value at least 1.2-fold (0.09 log units) from the limit.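

In this assay, within the data shown here, the exchange of 3-methylphenyl for methyl on an oxygen on a saturated carbon gives an at least 2.6-fold higher number from compound 1 to compound 4 (0.42 log units; beyond the scatter), the only step so far that can be read from one change in one place. This shows that the group at this place affects how much compound is tolerated, and that the six-membered aromatic ring of carbon only is not required at this place for the shared core and saturated chain to be tolerated in this assay. Compound 4 is reported only as a limit, so the step is a lower bound and its full size stays unknown: the limit of > 50 uM in this assay, at which 1 of the 4 values shown sits.

Open, going by these compounds, is whether the number changes gradually or abruptly along the range from methyl to 3-methylphenyl, for instance with an ethyl group, a cyclohexyl ring or a benzyl group on the same oxygen. Also open, on these data alone, is whether the same exchange gives a step of similar size on compound 2, which carries chlorine on the core, or with an amine or a carboxylic acid at the end of the chain.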